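The source may hold more compounds than are shown below. What is called first, only, known or untested is meant among the compounds shown, and "the series" means these compounds.

Three compounds share one core and differ only in the aryl group carried on a nitrogen on an aromatic ring. Compound 1 `CCc1ccc(Nc2cc(NC(=O)Nc3cc(OC)cc(OC)c3)ncn2)cc1` gives 50.1% in a functional assay on NCI-H226 cells (Homo sapiens) for inhibition, read by MTT assay, with a stated time of 48 h, tested at 10 uM; a lower number here means less inhibition, a higher number more inhibition at the concentration tested (going by the name of the read-out). Compound 2 `COc1cc(NC(=O)Nc2cc(Nc3ccc(C)c(C)c3)ncn2)cc(OC)c1` gives 45.3% in this assay, and compound 3 `COc1cc(NC(=O)Nc2cc(Nc3ccc(C)c(F)c3)ncn2)cc(OC)c1` gives 39.7% in this assay. Compound 3 thus sits below compound 1 by a step that is beyond the scatter (a number 10.4 percentage points lower from compound 1 to compound 3 (beyond the scatter)), while its distance from compound 2 (a number 5.6 percentage points lower from compound 2 to compound 3 (within the scatter)) and the step of a number 4.8 percentage points lower from compound 1 to compound 2 (within the scatter) both stay within the scatter.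

Compound 4 `COc1cc(NC(=O)Nc2cc(Nc3cc(F)ccc3OC)ncn2)cc(OC)c1` continues the same series of exchanges at that nitrogen: 5-fluoro-2-methoxyphenyl in place of 3-fluoro-4-methylphenyl on a nitrogen on an aromatic ring. All three measured steps concern this one aryl group, and the largest of them was only modest, so the exchange is expected to move this assay by no more than the scatter, in no preferred direction, giving an expected step of a number 0.3 percentage points higher from compound 3 to compound 4 (within the scatter). Compound 4 is therefore estimated at 40%, within a range from 25% to 55%.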

Compound 4, a percentage reported as inhibition, at one concentration (the size of the read-out at that concentration, not a potency): 37.7%
Estimate against measurement, compound 4: 2.3 percentage points above; the measured number falls inside the stated range.
By their numbers in this assay, from the lowest: compounds 4, 3, 2 and 1 (each within the scatter of the next, the first and the last beyond it).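

Putting 5-fluoro-2-methoxyphenyl in place of 3-fluoro-4-methylphenyl on the nitrogen adds an oxygen and a hydrogen-bond acceptor to the aryl group, yet this assay shows only a number 2 percentage points lower from compound 3 to compound 4 (within the scatter), and the exchange for 3,4-dimethylphenyl gives a number 7.6 percentage points lower from compound 2 to compound 4 (within the scatter). Only the exchange for 4-ethylphenyl passes the scatter, with a number 12.4 percentage points lower from compound 1 to compound 4 (beyond the scatter), a modest step that shows an aryl group with a methoxy substituent also stands apart from compound 1, as the 3-fluoro-4-methylphenyl group already did. No measurement at hand accounts for these differences.

The compounds shown leave open whether a dimethylamino group or a carboxylic acid on this phenyl ring would move the number further than these exchanges did. They also leave open how the groups compare as potencies, since every number here comes from a single concentration.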